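This account rests on a few compounds, and the source may have more. Where it says the series, first, only, none or still open, it means among the compounds named here.

The measured compounds in this study are these. Compound 1, `COc1ccc(N(Cc2ccc([N+](=O)[O-])cc2)Cc2ccccc2OC)cc1`, in a functional assay on L929 cells (Mus musculus) for inhibition, read by MTT assay, with a stated time of 5 days (on this read-out higher numbers stand for weaker inhibition and lower numbers for stronger inhibition), gives a limit, > 40 ug/mL. Compound 2, `COc1ccc(N(Cc2ccccc2)Cc2ccc([N+](=O)[O-])cc2)cc1`, in this assay also gives a limit, > 40 ug/mL. For the measured compounds named here, compound 3, `COc1ccc(NCc2ccccc2)cc1`, in this assay gives 30 ug/mL, the only number among the three.

Compound 4, `COc1ccc(NCc2ccccc2OC)cc1`, has not yet been measured. It differs from compound 3 by methoxy in place of hydrogen on an aromatic carbon. The same change has been made once before, from compound 2 to compound 1, as methoxy in place of hydrogen on an aromatic carbon, and there it gave a step that the two limits leave unreadable from compound 2 to compound 1, which is unreadable because of the limit of > 40 ug/mL in this assay, at which 2 of the 3 values shown sit. How the core of compound 3 differs from the core of compound 2 is not broken down here.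

Going by the values given here, with the one earlier step unreadable, there is no measured size to carry over, so the expectation rests on compound 3 alone, which gives 30 ug/mL. The step is expected to be a 1.2-fold higher number from compound 3 to compound 4 (0.07 log units; within the scatter). Compound 4 is therefore estimated to give 35 ug/mL, in a range from 15 ug/mL to 80 ug/mL.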

Compound 4, half-maximal inhibitory concentration: 25 ug/mL
Compound 4: the middle estimate sits 1.4-fold (0.15 log units) above what was measured; measured number inside the range.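

In this assay, methoxy in place of hydrogen on an aromatic carbon gives a 1.2-fold lower number from compound 3 to compound 4 (0.08 log units; within the scatter), so on the core of compound 3 the change stays within the scatter. That shows what the change does on this one core and gives the only readable size for it in the compounds shown. The earlier step from compound 2 to compound 1 cannot be read, so nothing shows whether the same small step holds on that other core, and the comparison between the two cores stays empty because of this: the limit of > 40 ug/mL in this assay, at which 2 of the 4 values shown sit.

The compounds shown leave open what other groups in the same place, such as a hydroxy group, a chlorine atom or an amine, would give on the core of compound 3. They also leave open how methoxy would read on a further core whose parent compound gives a number rather than a limit.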